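The compounds below may be only part of what the source reports. "The series", "measured", "known", "first", "only" and "open" are said of these compounds alone.

Measured in a functional assay on HCT-15 cells (Homo sapiens) for cytotoxicity; a higher number here means that more compound is needed for the effect, a lower number that less compound is needed:
compound 1 `C=CCCCCCC#CC#CC(O)CC(C)=O`, 3.42 ug/mL
compound 2 `C=CCCCCCCCC#CC#CC(O)CC(C)=O`, 4.18 ug/mL

Among the measured compounds shown here, compound 2 and compound 1 sit within the scatter of each other; the only step is a 1.2-fold higher number from compound 1 to compound 2 (0.09 log units; within the scatter). Compound 3 `C=CCCCCCCCC#CC#CCOCC(=O)O` differs from compound 2 by (carboxymethoxy)methyl in place of 2-acetyl-1-hydroxyethyl on a triple-bonded carbon. For the measured compounds named here, the step from compound 1 to compound 2 concerns but-3-en-1-yl in place of vinyl on a saturated chain carbon and does not touch the group on the triple-bonded carbon, so no measured step bears on this change. Without a guide, the expectation for compound 3 is a step of a 1.4-fold higher number from compound 2 to compound 3 (0.16 log units; within the scatter), with a wide range. Compound 3 is estimated at 6 ug/mL, between 2 ug/mL and 25 ug/mL.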

Compound 3, concentration for half-maximal effect: 4.47 ug/mL
Compound 3: the middle estimate sits 1.3-fold (0.13 log units) above what was measured; the range from low to high includes it.
By their numbers in this assay, from the lowest: compounds 1, 2 and 3 (each within the scatter of the next).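

With this assay, (carboxymethoxy)methyl in place of 2-acetyl-1-hydroxyethyl on a triple-bonded carbon gives a 1.1-fold higher number from compound 2 to compound 3 (0.03 log units; within the scatter). Among the compounds shown here, this is the first reading at this end of the molecule, as the earlier step concerned only the saturated chain, and it shows that this exchange of one group for the other does not move the number beyond the scatter. No supporting data bear on the reason for this result.

Going by these compounds, whether an amine or a plain hydroxymethyl on the triple-bonded carbon would also stay within the scatter remains open. So does the outcome of the same exchange on the core of compound 1.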